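This account rests on a few compounds, and the source may have more. Where it says the series, first, only, none or still open, it means among the compounds named here.

In an ADME assay on MRC5 cells (Homo sapiens) for cytotoxicity, read by MTT assay, with a stated time of 72 h (a lower number here means that less compound is tolerated, a higher number that more compound is tolerated), compound 1 (`OC[C@H]1O[C@@H](n2cc(Cl)c3c(-c4ccco4)ncnc32)[C@H](O)[C@@H]1O`) reads > 50000 nM as a limit of the assay. Compound 2 (`CCCCCCCCCCCCCCCCCCOP(=O)(O)OC[C@H]1O[C@@H](n2ccc3c(-c4ccccc4)ncnc32)[C@H](O)[C@@H]1O`) likewise reads > 50000 nM as a limit. Among the measured compounds shown here, compound 3 (`CCCCCCCCCCCCCCCCCCOP(=O)(O)OC[C@H]1O[C@@H](n2ccc3c(-c4ccco4)ncnc32)[C@H](O)[C@@H]1O`) gives 45300 nM as the only true number so far. The other two readings stand at the limit of > 50000 nM in this assay, at which 2 of the 3 values shown sit, and offer no number to rank it against. Compound 4 (`CCCCCCCCCCCCCCCCCCOP(=O)(O)OC[C@H]1O[C@@H](n2ccc3c(-c4ccoc4)ncnc32)[C@H](O)[C@@H]1O`) carries furan-3-yl in place of furan-2-yl on an aromatic carbon and otherwise matches compound 3. For the measured compounds named here, the one measured step bearing on this is an at least 1.1-fold lower number from compound 2 to compound 3 (0.04 log units; that floor lies within the scatter) for furan-2-yl in place of phenyl, so the swap between the two furans is expected to leave this assay within the scatter, with no direction favoured. The expected step is a 1.1-fold lower number from compound 3 to compound 4 (0.03 log units; within the scatter) and it is not expected to exceed the scatter. Compound 4 is estimated at 42000 nM with an expected range of 22000 nM to 50000 nM and a real chance that the assay reports only its limit.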

Compound 4, half-maximal cytotoxic concentration: > 50000 nM
Compound 4: only a limit was reported (the forecaster's own chance of this, stated with the estimate: 35%); middle value at least 1.1-fold (0.07 log units) from the limit.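

In this assay, furan-3-yl in place of furan-2-yl on this aromatic carbon gives an at least 1.1-fold higher number from compound 3 to compound 4 (0.04 log units; that floor lies within the scatter); this figure is only a floor and lies within the scatter, so the two furan attachments cannot be ordered here. The step from compound 2 to compound 4 cannot be read, as both readings are limits. Phenyl, furan-2-yl and furan-3-yl on this carbon therefore give no readable trend, and the series remains crowded at the top of the range: the limit of > 50000 nM in this assay, at which 3 of the 4 values shown sit.

From the compounds shown here alone, whether an amine or a carboxylic acid on this aromatic carbon would give a reading clearly below the limit remains open. Compound 1 differs from compound 3 in more than one place, so it does not show what any single change contributes.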